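The compounds below may be only part of what the source reports. "The series", "measured", "known", "first", "only" and "open" are said of these compounds alone.

In a functional assay on cells (Neutrophil, Rattus norvegicus) for inhibition (a lower number here means a stronger inhibitor, a higher number a weaker inhibitor), compound 1 `COc1ccc(OC)c(C(=O)/C=C/c2ccco2)c1` gives 6200 nM. Among the compounds with values here, this is the only exact number available so far, which makes compound 1 the reference point for what follows. Within the data shown here, its one measured neighbour is compound 2 `COc1ccc(OC)c(C(=O)/C=C/c2ccc(C)s2)c1`, which has 5-methylthiophen-2-yl in place of furan-2-yl. Compound 2 reads > 30000 nM, and this is a limit of the assay, not a number.

The next structure is compound 3 `COc1ccc(OC)c(C(=O)/C=C/c2occc2Br)c1`, which keeps the furan of compound 1 and changes only one position on it: bromo in place of hydrogen on an aromatic carbon. Furan-2-yl thus becomes 3-bromofuran-2-yl. Among the measured compounds shown here, the only measured step that bears on this is an at least 4.8-fold higher number from compound 1 to compound 2 (0.68 log units; beyond the scatter). That step replaces the whole ring group, whereas compound 3 differs by a single atom, so it is a loose guide. It does show that a change in this part of compound 1 can weaken inhibition, but one step establishes no pattern.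

A small move towards a weaker inhibitor is therefore expected, possibly no larger than the usual scatter, and the estimated step is a 1.3-fold higher number from compound 1 to compound 3 (0.11 log units; within the scatter). In this assay, compound 3 is estimated at 8000 nM, with an expected range of 2000 nM to 28000 nM.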

Compound 3, half-maximal inhibitory concentration: > 30000 nM
Compound 3: only a limit was reported; the forecaster's own chance of this, stated with the estimate: 20%; middle value at least 3.7-fold (0.57 log units) from the limit.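

A single atom is enough to change the picture: bromo in place of hydrogen on an aromatic carbon of the furan gives an at least 4.8-fold higher number from compound 1 to compound 3 (0.68 log units; beyond the scatter), so in this assay a loss of inhibition beyond the scatter does not require replacing the whole ring group, as it did in compound 2. From the compounds shown here alone, compound 3 reads > 30000 nM, which is a limit of the assay and not a number, so the step shows only the smallest possible size of the loss, and the true size remains unknown. The step between compound 2 and compound 3 cannot be read, and the two compounds cannot be ranked against each other: the limit of > 30000 nM in this assay, at which 2 of the 3 values shown sit.

Still open, going by these compounds, is whether this carbon of the furan accepts any group at all, for instance a fluoro, a methyl or an amine in place of the same hydrogen, or whether the loss is specific to bromo. Also open, on these data alone, is whether bromo on the other aromatic carbons of the furan would weaken inhibition in the same way.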